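The source may report more compounds than this note shows. Statements on the series, on what has been measured and on what is new or still open speak of the compounds shown alone.

Working notes on the series. Among the compounds with values here, compound 1 `CCCCCCOc1ccc2c(=O)c(-c3ccc(O)cc3)coc2c1` is the only member with a numerical reading: in an assay (Cricetulus griseus) for inhibition of aldehyde dehydrogenase, mitochondrial (Homo sapiens) (a higher number here means a weaker inhibitor, a lower number a stronger inhibitor), compound 1 gives 1500 nM. Compound 2 `O=C(O)COc1ccc(-c2coc3cc(OCC(=O)O)ccc3c2=O)cc1` is reported in this assay only as a limit, >> 9000 nM, not as a number. Within what is shown, compound 2 sits at the limit of >> 9000 nM in this assay, at which 1 of the 2 values shown sits, so compound 1 is the sole point against which a new compound can be set; no measured step between two compounds exists yet.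

The step to be followed runs from compound 1 to compound 3 `CCOC(=O)CCCCCOc1ccc2c(=O)c(-c3ccc(O)cc3)coc2c1`. The change is ethoxycarbonyl in place of methyl on a saturated chain carbon, five bonds along the chain from an oxygen on an aromatic ring. Nothing measured bears directly on this exchange, and no cause for any outcome is offered.

Expectation: the step from compound 1 to compound 3 is estimated at a 1.7-fold higher number from compound 1 to compound 3 (0.22 log units; within the scatter), a modest weakening at most, little beyond the scatter, taking the reading of compound 1 at 1500 nM as the anchor. Compound 3 is therefore expected to give about 2500 nM in this assay, estimated between 900 nM and 7000 nM.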

Compound 3, half-maximal inhibitory concentration: 280 nM
Estimate against measurement, compound 3: 8.9-fold (0.95 log units) above; the whole stated range lies above it.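

In this assay, within the data shown here, the series now has its only measured step, a 5.4-fold lower number from compound 1 to compound 3 (0.73 log units; beyond the scatter): the place on a saturated chain carbon, five bonds along the chain from an oxygen on an aromatic ring, accepts ethoxycarbonyl in place of methyl, and the number falls rather than rises. With compound 1 as the sole earlier number, nothing had yet shown that a change at this place could move the reading at all, and the entering group brings 2 hydrogen-bond acceptors with no ring and no net charge. Nothing shown gives a cause for this step.

Which part of the ethoxycarbonyl group goes with the lower number stays open, as does how a primary amide, an amine or a longer chain would read at the same place. Compound 2 is reported only as a limit, >> 9000 nM, and differs from compound 1 in more than one place, so it does not settle how a carboxylic acid at the end of this chain would read.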